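Sulfonyl in place of the bromobenzoyl acyl group

The source may hold more compounds than are shown below. What is called first, only, known or untested is meant among the compounds shown, and "the series" means these compounds.

Among the compounds with values here, compound 2 `O=C(NC(=S)N1CCc2c(OCCCCCOc3ccc(Cl)cc3)cccc21)c1ccc(Br)cc1` gives 29100 nM in an ADME assay on Huh-7 cells (Homo sapiens) for cytotoxicity (a lower number here means that less compound is tolerated, a higher number that more compound is tolerated), the highest of the two numbers so far. The nearest is compound 1 `O=C(NC(=S)N1CCc2c(OCCCCCOc3ccc(Cl)cc3)cccc21)c1ccc([N+](=O)[O-])cc1` with 13600 nM; the step of a 2.1-fold higher number from compound 1 to compound 2 (0.33 log units; beyond the scatter). Compound 3 `O=C(NC(=S)N1CCc2c(OCCCCCOc3ccc(Cl)cc3)cccc21)c1cc2ccccc2s1` returns only a limit, > 50000 nM. The step of an at least 1.7-fold higher number from compound 2 to compound 3 (0.23 log units; that floor lies within the scatter). Compound 4 `O=S(=O)(NC(=S)N1CCc2c(OCCCCCOc3ccc(Cl)cc3)cccc21)c1ccccc1` carries the change (phenylsulfonyl in place of (4-bromophenyl)carbonyl on an amide-type nitrogen). Both measured steps alter the group on the carbonyl carbon, and each moved the number upward by a modest amount; neither exchanges the carbonyl itself for a sulfonyl, so they serve only as a loose guide. The estimated step of a 1.2-fold higher number from compound 2 to compound 4 (0.09 log units; within the scatter) is therefore small and upward. Compound 4 is expected to give 36000 nM, in the range 15000 nM to 80000 nM.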

Compound 4, half-maximal cytotoxic concentration: > 50000 nM
Compound 4 was reported as a limit; the forecaster's own chance of this, stated with the estimate: 30%; at least 1.3-fold (0.14 log units) between middle value and limit.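

In this assay the exchange of a carbonyl for a sulfonyl on the amide-type nitrogen brings no drop in the number: the step is an at least 1.7-fold higher number from compound 2 to compound 4 (0.23 log units; that floor lies within the scatter), and the wider step is an at least 3.6-fold higher number from compound 1 to compound 4 (0.56 log units; beyond the scatter). Compound 4 is reported only as a limit, and the step between compound 3 and compound 4 cannot be read. Readings in the series now stop at a ceiling: the limit of > 50000 nM in this assay, at which 2 of the 4 values shown sit.

From the compounds shown here alone, compound 4 changes the linking group and loses the bromo together, and their separate shares remain open. Also open, going by these compounds, is how (4-bromophenyl)sulfonyl or methylsulfonyl would read here.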